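This account rests on a few compounds, and the source may have more. Where it says the series, first, only, none or still open, it means among the compounds named here.

Working notes on the series. Compound 1 `O=C1C=CC(=O)C(c2cc(-c3ccc(C(=O)N4CCC(C(F)(F)F)CC4)s3)on2)=C1` is the starting point for the step taken up here. In a functional assay on A549 cells (Homo sapiens) for cytotoxicity, read by XTT assay, with a stated time of 72 h (on this read-out higher numbers stand for weaker inhibition and lower numbers for stronger inhibition), compound 1 gives only a limit, > 30000 nM. Compound 2 `COc1ccc(OC)c(-c2cc(-c3ccc(C(=O)NC4CC4)s3)on2)c1` also returns a limit in this assay, > 30000 nM. Compound 3 `COc1ccc(OC)c(-c2cc(-c3ccc(C(=O)N4CCC(C(F)(F)F)CC4)s3)on2)c1` likewise sits at a limit in this assay, > 30000 nM. Among the compounds with values here, the step that the two limits leave unreadable from compound 1 to compound 3 and the step that the two limits leave unreadable from compound 2 to compound 3 are therefore both unreadable, and every value so far rests at the limit of > 30000 nM in this assay, at which 3 of the 3 values shown sit.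

Compound 4 `O=C1C=CC(=O)C(c2cc(-c3ccc(C(=O)N4CCCC4)s3)on2)=C1` differs from compound 1 in a single place: pyrrolidin-1-yl in place of 4-(trifluoromethyl)piperidin-1-yl on a carbonyl carbon. Within the data shown here, the only measured step that also falls on the carbonyl carbon, a step that the two limits leave unreadable from compound 2 to compound 3, yields no readable size, so no measured step sets either a size or a direction for this change in this assay. With all three shown values at the limit, the working expectation is that compound 4 stays there too. Compound 4 is expected to come in at about 30000 nM, estimated between 10000 nM and 100000 nM. The estimated step of a number no higher from compound 1 to compound 4 (the limit leaves the size open) is thus expected to be none beyond the scatter, with a limit rather than a number the most likely outcome.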

Compound 4, half-maximal inhibitory concentration: > 30000 nM
Compound 4: only a limit was reported; the forecaster's own chance of this, stated with the estimate: 85%; the middle value lies on the limit itself.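

Compound 1 and compound 4 both rest at limits, so no new step can be read between them, and the values shown stay at one limit: the limit of > 30000 nM in this assay, at which 4 of the 4 values shown sit.

The compounds shown leave open which structural change, if any, would give a readable value in this assay.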